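Swapping the end group of a peptide aldehyde inhibitor

This account rests on a few compounds, and the source may have more. Where it says the series, first, only, none or still open, it means among the compounds named here.

Measured so far:
Compound 1, `CC(=O)N[C@@H](CO)C(=O)N[C@@H](C)C(=O)N[C@H](C(=O)N[C@@H](CC(C)C)C(=O)N[C@H](C=O)CCC(=O)N(C)C)C(C)C`: 37000 nM
Compound 2, `CC(=O)N[C@@H](CO)C(=O)N[C@@H](C)C(=O)N[C@H](C(=O)N[C@@H](CC(C)C)C(=O)N[C@H](C=O)C(C)(C)C)C(C)C`: 3000000 nM

Both compounds share a short peptide core ending in an aldehyde, and both were tested in an assay for inhibition of chymotrypsin-like protease CTRL-1 variant R188I (Homo sapiens), read by HPLC, with stated times of 20 min and 60 min; on this read-out higher numbers stand for weaker inhibition and lower numbers for stronger inhibition. Among the measured compounds shown here, compound 2 carries the highest of the two numbers; its nearest neighbour is compound 1, and the step of an 81-fold higher number from compound 1 to compound 2 (1.91 log units; beyond the scatter) is the only measured step here.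

The next compound, compound 3, `CC(=O)N[C@@H](CO)C(=O)N[C@@H](C)C(=O)N[C@H](C(=O)N[C@@H](CC(C)C)C(=O)N[C@H](C=O)CC1CCCCC1)C(C)C`, keeps the whole core of compound 2 and changes only the group on the chain carbon next to the aldehyde: cyclohexylmethyl in place of tert-butyl on a saturated chain carbon bound to an amide-type nitrogen and a carbonyl carbon.

For the measured compounds named here, no measured pair makes exactly this change. Going by the values given here, the single step on record, an 81-fold higher number from compound 1 to compound 2 (1.91 log units; beyond the scatter), shows that this position responds strongly to what is attached there, and that the tert-butyl of compound 2 gives by far the weaker of the two results. Replacing that group with cyclohexylmethyl is therefore expected to move the number downward, that is toward stronger inhibition in this assay, by a large margin a 100-fold lower number from compound 2 to compound 3 (2.00 log units; beyond the scatter), though the exact size is uncertain. For compound 3 the estimate in this assay is 30000 nM, within a range from 3000 nM to 400000 nM.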

Compound 3, half-maximal inhibitory concentration: 62000 nM
Estimate against measurement, compound 3: 2.1-fold (0.32 log units) below, within the range that was stated.
By their numbers in this assay, from the lowest: compounds 1 and 3 (each within the scatter of the next); then compound 2.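

In this assay, on a saturated chain carbon bound to an amide-type nitrogen and a carbonyl carbon, putting cyclohexylmethyl in place of tert-butyl gives a 48-fold lower number from compound 2 to compound 3 (1.68 log units; beyond the scatter), so the weak result of compound 2 is not simply what follows from losing the 2-(dimethylcarbamoyl)ethyl group of compound 1. A group made of carbon only, with one six-membered ring, can give a number in the same range, as the comparison with the dimethylamide-bearing chain shows: a 1.7-fold higher number from compound 1 to compound 3 (0.22 log units; within the scatter), which means these two groups cannot be told apart in this assay. Nothing available explains why either group differs so strongly from tert-butyl.

The three compounds leave open whether the cyclohexyl ring itself matters, or whether a simpler group such as isobutyl or a straight butyl chain would give a similar number. They also leave open how a benzyl group, or a chain ending in a carboxylic acid or an amine, would behave at this same position.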